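A trifluoromethyl swap on compound 2

The source may hold more compounds than are shown below. What is called first, only, known or untested is meant among the compounds shown, and "the series" means these compounds.

In an ADME assay on Vero cells (Chlorocebus sabaeus) for cytotoxicity, read by MTT assay, with a stated time of 24 h (a lower number here means that less compound is tolerated, a higher number that more compound is tolerated), compound 1 (`Nc1nc(N)c2cc(NCc3ccc4c(c3)OCCO4)ccc2n1`) gives > 200000 nM as a limit of the assay. Compound 2 (`CN(C)CCCOc1ccc(CNc2ccc3nc(N)nc(N)c3c2)cc1`) gives > 200000 nM as a limit also. The place of compound 2 is thus the limit of > 200000 nM in this assay, at which 2 of the 3 values shown sit, and no number can be given for it. Compound 3 (`COc1ccc(CNc2ccc3nc(NC(C)=O)nc(NC(C)=O)c3c2)cc1`) reads 156000 nM as a true number. Compound 4 (`Nc1nc(N)c2cc(NCc3ccc(OC(F)(F)F)cc3)ccc2n1`) differs from compound 2 by trifluoromethyl in place of 3-(dimethylamino)propyl on an oxygen on an aromatic ring. Among the compounds with values here, no measured pair differs in one place only, so the data offer no direct guide. The estimated step of an at least 1.1-fold lower number from compound 2 to compound 4 (0.07 log units; that floor lies within the scatter) is expected to stay within the scatter, with any drift towards less compound tolerated. Compound 4 is estimated at 170000 nM in this assay with a range of 80000 nM to 300000 nM expected.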

Compound 4, half-maximal cytotoxic concentration: 182000 nM
The estimate for compound 4 lay 1.1-fold (0.03 log units) below the measured number; measured number inside the range.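

On the oxygen on an aromatic ring, trifluoromethyl in place of 3-(dimethylamino)propyl gives a step that can now be read in this assay: an at least 1.0-fold lower number from compound 2 to compound 4 (0.04 log units; that floor lies within the scatter). Compound 4 thus gives a true number for a compound with this oxygen substituent and no nitrogen in it. The step remains only a floor, because compound 2 stands at a limit: the limit of > 200000 nM in this assay, at which 2 of the 4 values shown sit.

On these data alone, how far the true step reaches remains open. So does how a carboxylic acid, a primary amine or a longer chain on this oxygen would read.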